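The compounds below may be only part of what the source reports. "The series", "measured", "known", "first", "only" and "open" are said of these compounds alone.

Measured compounds in this series:
compound 1, `CCOc1ccccc1Nc1nc(SCc2ccc(C(F)(F)F)cc2)nc2ccccc12`: > 50000 nM
compound 2, `FC(F)(F)c1ccc(CSc2nc(Nc3cccc(C(F)(F)F)c3)c3ccccc3n2)cc1`: 11100 nM
compound 3, `O=[N+]([O-])c1ccc(Nc2nc(SCc3ccc(C(F)(F)F)cc3)nc3ccccc23)cc1`: 8670 nM

In a functional assay on MDA-MB-231 cells (Homo sapiens) for cytotoxicity, read by MTT assay, with a stated time of 72 h (on this read-out higher numbers stand for weaker inhibition and lower numbers for stronger inhibition), the value of compound 1 is a limit of the assay and not a number. In this assay compound 2 gives 11100 nM and compound 3 gives 8670 nM; these two sit within the scatter of each other, a 1.3-fold lower number from compound 2 to compound 3 (0.11 log units; within the scatter), so neither can be set apart from the other. The steps from compound 1 are larger, an at least 4.5-fold lower number from compound 1 to compound 2 (0.65 log units; beyond the scatter) and an at least 5.7-fold lower number from compound 1 to compound 3 (0.76 log units; beyond the scatter), both beyond the scatter, though each is bounded only by the limit (the limit of > 50000 nM in this assay, at which 1 of the 3 values shown sits).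

Compound 4, `Cc1ccc(Nc2nc(SCc3ccc(C(F)(F)F)cc3)nc3ccccc23)cc1`, differs from compound 3 by methyl in place of nitro on an aromatic carbon. Within the data shown here, no measured step exchanges methyl for nitro. The steps from compound 1 show that the substituent on this aromatic carbon can move the number in this assay beyond the scatter, while the step from compound 2 to compound 3 shows two different substituents giving numbers within the scatter. The expected step is therefore small and uncertain, a 1.7-fold higher number from compound 3 to compound 4 (0.24 log units; within the scatter), with a real chance that only a limit is returned. Compound 4 is estimated at 15000 nM, between 5000 nM and 50000 nM.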

Compound 4, half-maximal inhibitory concentration: > 50000 nM
Compound 4: no number, only a limit; the forecaster's own chance of this, stated with the estimate: 25%; middle value at least 3.3-fold (0.52 log units) away from the limit.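

In this assay compound 4 gives > 50000 nM as a limit of the assay and not a number, and the step linking it to compound 1 cannot be read: the limit of > 50000 nM in this assay, at which 2 of the 4 values shown sit. Methyl in place of nitro on this aromatic carbon, para to a large group, with the rest of the structure unchanged, is enough to move the read-out beyond the scatter (an at least 5.7-fold higher number from compound 3 to compound 4 (0.76 log units; beyond the scatter)), whereas the earlier readable steps exchanged whole substituted phenyl groups. The 4-methylphenyl group also separates from the 3-(trifluoromethyl)phenyl group (an at least 4.5-fold higher number from compound 2 to compound 4 (0.65 log units; beyond the scatter)), so among the compounds shown a phenyl group on this nitrogen does not by itself give a number in this assay.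

On these data alone, with only nitro and methyl compared on this aromatic carbon, no trend across substituents can be drawn, and it remains open how an amine, a methoxy group or a carboxylic acid at the same place would read. The limits also leave open any order between compound 1 and compound 4.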